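The source may report more compounds than this note shows. Statements on the series, on what has been measured and on what is new or still open speak of the compounds shown alone.

Measured compounds:
- compound 1 `O=S(=O)(/C=C/c1ccccc1)Nc1ccc(Cl)cc1`: 20000 nM
- compound 2 `COC(=O)C(C)(C)Nc1cc(NS(=O)(=O)/C=C/c2c(OC)cc(OC)cc2OC)ccc1OC`: 200 nM

Working notes. In a functional assay on DU-145 cells (Homo sapiens) for cytotoxicity, read by trypan blue exclusion, with a stated time of 96 h (on this read-out higher numbers stand for weaker inhibition and lower numbers for stronger inhibition), compound 1 gives 20000 nM and compound 2 gives 200 nM. Compound 2 stands lowest of the two numbers; the gap to compound 1 is well beyond the scatter, and the two structures differ in several places at once, so nothing is drawn from that pair about any single group.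

Compound 3 `COc1cc(OC)c(/C=C/S(=O)(=O)Nc2ccc(OC)c(NC(C(=O)O)c3ccc(F)cc3)c2)c(OC)c1` is not yet measured in this assay. It differs from compound 2 in one place: carboxy(4-fluorophenyl)methyl in place of 1-(methoxycarbonyl)-1-methylethyl on a nitrogen on an aromatic ring

Going by the values given here, no single-change step between measured compounds is available, so the size of this step cannot be read from data. The expectation for compound 3 is a modest move toward weaker inhibition, a 3.0-fold higher number from compound 2 to compound 3 (0.48 log units; beyond the scatter), which may still fall within the scatter. On that basis compound 3 is estimated at 600 nM in this assay, with a range from 150 nM to 3000 nM.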

Compound 3, half-maximal inhibitory concentration: 75 nM
Compound 3: the middle estimate sits 8.0-fold (0.90 log units) above what was measured; measured number below the stated range.
By their numbers in this assay, from the lowest: compound 3; then compound 2; then compound 1.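

In this assay, the place on a nitrogen on an aromatic ring accepts a much larger group without loss: carboxy(4-fluorophenyl)methyl in place of 1-(methoxycarbonyl)-1-methylethyl gives a 2.7-fold lower number from compound 2 to compound 3 (0.43 log units; beyond the scatter) and so keeps the series in its low range. The incoming group brings one six-membered aromatic ring and a hydrogen-bond donor, and neither addition costs anything on this read-out. Several features change in this one step, and no information on why the number falls accompanies the result.

The compounds shown do not separate the contribution of the carboxy group from that of the 4-fluorophenyl ring. The open comparisons are 1-carboxy-1-methylethyl, which would place the carboxylic acid on the earlier chain, and (methoxycarbonyl)(4-fluorophenyl)methyl, which would place the methyl ester beside the aromatic ring.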